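The source may hold more compounds than are shown below. What is called first, only, known or untested is meant among the compounds shown, and "the series" means these compounds.

Compound 3 `COc1ccc(O)c(C(=O)OC/C=C(C)/C=C/C=C(C)/C=C/C2=CCCCC2(C)C)c1` stands highest of the three measured esters in a toxicity assay on cells (Fibroblast, Homo sapiens) for cytotoxicity (a higher number here means a weaker inhibitor, a lower number a stronger inhibitor), at 570000 nM, against compound 1 `CC(/C=C/C1=CCCCC1(C)C)=C\C=C\C(C)=C\COC(=O)c1c(O)cccc1O` at 14000 nM and compound 2 `COc1cccc(C(=O)OC/C=C(C)/C=C/C=C(C)/C=C/C2=CCCCC2(C)C)c1O` at 27000 nM. The next structure, compound 4 `COc1cc(O)c(C(=O)OC/C=C(C)/C=C/C=C(C)/C=C/C2=CCCCC2(C)C)c(O)c1`, is reached from compound 3 by one change: a group of 10 heavy atoms (7 carbon, 3 oxygen; one six-membered aromatic ring of carbon only) in place of a group of 9 heavy atoms (7 carbon, 2 oxygen; one six-membered aromatic ring of carbon only), on a carbonyl carbon.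

Within the data shown here, two measured steps bear on this change: a 41-fold higher number from compound 1 to compound 3 (1.61 log units; beyond the scatter) and a 21-fold higher number from compound 2 to compound 3 (1.32 log units; beyond the scatter). Both are large, while a 1.9-fold higher number from compound 1 to compound 2 (0.29 log units; within the scatter) stays within the scatter. Compound 3 therefore sits apart, and compounds 1 and 2 sit together. The entering group has more in common with the group carried by compound 1, at 14000 nM, than with the leaving group, so compound 4 is expected to fall in with that pair. Among the measured compounds shown here, the data hold no direct precedent for this exact group, so the range stays wide.

A large step to a lower number is therefore expected in this assay, estimated as a 19-fold lower number from compound 3 to compound 4 (1.28 log units; beyond the scatter). For compound 4 the estimated value is 30000 nM, with an expected range of 10000 nM to 120000 nM.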

Compound 4, half-maximal inhibitory concentration: 14000 nM
Beside the measured number, compound 4's estimate is 2.1-fold (0.33 log units) above it; the measured number falls inside the stated range.
By their numbers in this assay, from the lowest: compounds 1, 4 and 2 (each within the scatter of the next); then compound 3.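

In this assay, methoxy in place of hydrogen on an aromatic carbon of the group on the carbonyl carbon leaves the read-out unmoved, with no change at the digits printed from compound 1 to compound 4 (within the scatter) as the step. A methoxy group alone therefore does not set compound 3 apart: a 41-fold lower number from compound 3 to compound 4 (1.61 log units; beyond the scatter) is a large step, whereas a 1.9-fold lower number from compound 2 to compound 4 (0.29 log units; within the scatter) stays within the scatter, so compounds 2 and 4, both methoxy-bearing, sit together. Nothing shown accounts for the gap between the 2-hydroxy-5-methoxyphenyl group and the entering group.

Still open, as far as these compounds go, is whether an ethoxy group, an amine or a carboxylic acid on the same aromatic ring would keep the read-out with compounds 1, 2 and 4 or move it towards compound 3. Also open, from the compounds shown here alone, is how the ester linkage itself contributes, for instance if an amide replaced it.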